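This account rests on a few compounds, and the source may have more. Where it says the series, first, only, none or still open, it means among the compounds named here.

Compound 1 `CC(C)OC(=O)N1CCC(Oc2ncnc3c2CCN3c2ccc(S(C)(=O)=O)cc2F)CC1` gives 50.1 nM in a functional assay on CHO-K1 cells for agonist activity at Glucose-dependent insulinotropic receptor (Homo sapiens), read by a luciferase reporter, with a stated time of 5 h; a lower number here means that less compound is needed, a higher number that more compound is needed for the effect. Compound 2 `CC(C)OC(=O)N1CCC(Oc2ncnc3c2CCN3c2ccc(F)cn2)CC1` reaches only the limit of this assay, > 10000 nM, in this assay. Compound 3 `CSc1ccc(N2CCc3c(OC4CCN(C(=O)OC(C)C)CC4)ncnc32)cc1F` gives 398 nM in this assay, and it stands with the highest of the two numbers shown, its nearest neighbour being compound 1. The step of an at least 190-fold higher number from compound 1 to compound 2 (2.30 log units; beyond the scatter) is large, the step of a 7.9-fold higher number from compound 1 to compound 3 (0.90 log units; beyond the scatter) is modest, and the step of an at least 25-fold lower number from compound 2 to compound 3 (1.40 log units; beyond the scatter) is large.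

Compound 4 `CC(C)OC(=O)N1CCC(Oc2ncnc3c2CCN3c2ccc([S@+](C)[O-])c(F)c2)CC1` is not yet measured in this assay. It differs from compound 3 by a group of 3 heavy atoms (1 carbon, 1 oxygen, 1 sulfur; no ring) in place of a group of 2 heavy atoms (1 carbon, 1 sulfur; no ring), on an aromatic carbon. For the measured compounds named here, the step that bears on this change is the one from compound 1 to compound 3, in which the methylsulfonyl group gave way to methylsulfanyl and the number rose by a 7.9-fold higher number from compound 1 to compound 3 (0.90 log units; beyond the scatter). The change from compound 3 to compound 4 moves part of the way back toward compound 1, so a lower number is expected for compound 4, of smaller size than that step: the expected step is a 3.3-fold lower number from compound 3 to compound 4 (0.52 log units; beyond the scatter). Compound 4 is therefore estimated at 120 nM in this assay, with a range from 40 nM to 400 nM.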

Compound 4, half-maximal effective concentration: 50.1 nM
For compound 4 the middle estimate is 2.4-fold (0.38 log units) above the measured one, within the range that was stated.
By their numbers in this assay, from the lowest: compounds 1 and 4 (each within the scatter of the next); then compound 3. At a limit, above all of these: compound 2.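

Replacing methylsulfanyl on this aromatic carbon, ortho to a fluoro group, gives a 7.9-fold lower number from compound 3 to compound 4 (0.90 log units; beyond the scatter), so a change at this one group, with the rest of the molecule left as it is, moves the number beyond the scatter in this assay. The comparison with the 2-fluoro-4-(methylsulfonyl)phenyl group gives no change at the digits printed from compound 1 to compound 4 (within the scatter), so the two aryl groups cannot be told apart here, although they carry the fluoro group in different places. Against the 5-fluoropyridin-2-yl group the gap is an at least 190-fold lower number from compound 2 to compound 4 (2.30 log units; beyond the scatter), and its size is bounded only by a limit, not a number: the limit of > 10000 nM in this assay, at which 1 of the 4 values shown sits.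

The compounds shown leave open how the opposite configuration at the defined stereocentre of compound 4 would read, and how methylsulfonyl would read with the fluoro group placed as in compound 4. They also do not show what an amine or a carboxamide on this aromatic carbon would give.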